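Acetate to aryl ester in a weakly active series

The source may report more compounds than this note shows. Statements on the series, on what has been measured and on what is new or still open speak of the compounds shown alone.

Compound 1 `CC1=CCC2C(CC[C@@]2(C)O)C(C)(C)C1CC[C@@H]1[C@@]2(C)CCC(=O)C(C)(C)O[C@@H]2CC[C@]1(C)O` reaches only the assay limit: in a functional assay on MDA-MB-231 cells (Homo sapiens) for antiproliferative activity, read by MTT assay, with a stated time of 72 h (on this read-out higher numbers stand for weaker inhibition and lower numbers for stronger inhibition), compound 1 gives > 50000 nM, a limit rather than a number. Compound 2 `CC1=CC[C@H]2[C@@H]1CC=C(C)[C@@H](CC[C@H]1[C@]3(C)CC[C@H](O)C(C)(C)O[C@H]3CC[C@@]1(C)O)C2(C)C` likewise stops at a limit, giving > 50000 nM in this assay. For the measured compounds named here, compound 3 `CC(=O)O[C@H]1CC[C@]2(C)[C@H](CC[C@@](C)(O)[C@H]2CC[C@@H]2C(C)=CC[C@H]3[C@H](CC[C@]3(C)O)C2(C)C)OC1(C)C` is the one member with a measured number, 38000 nM in this assay. The other two values sit at the limit, as the limit of > 50000 nM in this assay, at which 2 of the 3 values shown sit, records. Going by the values given here, no step between measured compounds can be drawn from these values. Compound 4 `CC1=CC[C@H]2[C@H](CC[C@]2(C)O)C(C)(C)[C@@H]1CC[C@H]1[C@]2(C)CC[C@H](OC(=O)c3ccc(C(F)(F)F)cc3F)C(C)(C)O[C@H]2CC[C@@]1(C)O` is yet to be measured; it differs from compound 3 by 2-fluoro-4-(trifluoromethyl)phenyl in place of methyl on a carbonyl carbon, a change on a carbonyl carbon. Among the compounds with values here, with no measured step to lean on, the expected move from compound 3 to compound 4 in this assay is a 1.9-fold lower number from compound 3 to compound 4 (0.28 log units; within the scatter), a modest gain at best and possibly nothing beyond the scatter. Compound 4 is therefore estimated at 20000 nM, with a range from 5000 nM to 60000 nM.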

Compound 4, half-maximal inhibitory concentration: 36300 nM
Compound 4: the middle estimate sits 1.8-fold (0.26 log units) below what was measured; measured number inside the range.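

In this assay, for the compounds shown here, the first step gives a 1.0-fold lower number from compound 3 to compound 4 (0.02 log units; within the scatter): on this carbonyl carbon, an aromatic ring bearing fluorine and trifluoromethyl takes the place of methyl without separating the two values. This position therefore accepts a much larger group with no change that can be read in this assay. Compound 3 and compound 4 both remain measurable, short of the limit that bounds the series: the limit of > 50000 nM in this assay, at which 2 of the 4 values shown sit.

From the compounds shown here alone, whether any group here can move the value beyond the scatter remains open. An amine or a carboxylic acid on this carbonyl carbon's aromatic ring is untested among the compounds shown, as is a plain phenyl.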